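Stereoisomers of a polyhydroxylated piperidine acid

The source may report more compounds than this note shows. Statements on the series, on what has been measured and on what is new or still open speak of the compounds shown alone.

Compound 1 `O=C(O)[C@@H]1NC[C@@H](O)[C@@H](O)[C@H]1O`: 8.2%
Compound 2 `O=C(O)[C@H]1NC[C@H](O)[C@H](O)[C@H]1O`: 21%
Compound 3 `O=C(O)[C@H]1NC[C@@H](O)[C@H](O)[C@@H]1O`: 11%

Three measured compounds share one set of atoms and bonds and differ only in configuration. In an assay for inhibition of alpha-N-acetylgalactosaminidase (Gallus gallus), tested at 1000 uM (on this read-out higher numbers stand for more inhibition at the one concentration tested (going by the name of the read-out) and lower numbers for less inhibition), compound 1 gives 8.2%, compound 2 gives 21% and compound 3 gives 11%. Compound 2 has the highest number of the three; its gap to compound 3 is within the scatter, while its gap to compound 1 is beyond it: a number 12.8 percentage points higher from compound 1 to compound 2 (beyond the scatter), and the two differ only in configuration (the fact that compounds 1 and 2 differ only in the configuration as drawn). The other steps are smaller: a number 2.8 percentage points higher from compound 1 to compound 3 (within the scatter) and a number 10 percentage points lower from compound 2 to compound 3 (within the scatter).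

Compound 4 `O=C(O)[C@@H]1NC[C@H](O)[C@H](O)[C@H]1O` differs from compound 2 as follows: the two compounds have the same atoms and bonds and differ only in configuration as drawn: 1 of 4 stereo elements differ; a stereocentre at a saturated ring carbon is drawn S in compound 2 and R in compound 4. Among the compounds with values here, all three measured steps concern inversions of configuration, and only the one with three inverted centres rose beyond the scatter; the two- and three-centre steps between compounds 1, 2 and 3 stayed within it. A single inversion is a smaller change than any measured step, so a step within the scatter, or at most a modest fall, is expected in this assay: a number 6 percentage points lower from compound 2 to compound 4 (within the scatter). Compound 4 is therefore estimated at 15%, with a range from 4% to 30%.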

Compound 4, a percentage reported as inhibition, at one concentration (the size of the read-out at that concentration, not a potency): 4.4%
The estimate for compound 4 lay 10.6 percentage points above the measured number; measured number inside the range.
By their numbers in this assay, from the lowest: compounds 4, 1, 3 and 2 (each within the scatter of the next, the first and the last beyond it).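

Inverting a single saturated ring carbon, drawn S on one side and R on the other, is enough to give a number 16.6 percentage points lower from compound 2 to compound 4 (beyond the scatter) in this assay, the first one-centre step in the set and one that passes the scatter, whereas the earlier step to do so involved three inverted centres. The other two new steps stay within the scatter, a number 6.6 percentage points lower from compound 3 to compound 4 (within the scatter) with three centres inverted and a number 3.8 percentage points lower from compound 1 to compound 4 (within the scatter) with two, so among these four compounds the number of inverted centres does not track the size of the step. The gap at this one carbon arises with no atom entering or leaving: the fact that compounds 2 and 4 differ only in the configuration as drawn.

Within the data shown here, no other pair here differs at a single centre, so whether this inversion would matter in the same way on another stereoisomer stays open, and the finding rests on one step. Also open, going by these compounds, is what an amide or a methyl ester in place of the carboxylic acid, or a longer chain on the amine, would do to the read-out at either configuration of this carbon.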